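Series notes: carbonyl substituent and receptor agonism

The source may report more compounds than this note shows. Statements on the series, on what has been measured and on what is new or still open speak of the compounds shown alone.

Measured so far in an assay on HL-60 cells for agonist activity at vitamin D3 receptor (Homo sapiens), read by microscopy, with a stated time of 96 h; on this read-out lower numbers stand for an effect already at smaller amounts and higher numbers for an effect only at larger amounts of compound:
compound 1 `CCn1c(C(=O)NCC(OC)OC)ccc1C(CC)(CC)c1ccc(OCC(=O)C(C)(C)C)c(C)c1` gives 130 nM;
compound 2 `CCn1c(C(=O)NCCN)ccc1C(CC)(CC)c1ccc(OCC(=O)C(C)(C)C)c(C)c1` gives 120 nM;
compound 3 `CCn1c(C(=O)N(C)c2ccccc2)ccc1C(CC)(CC)c1ccc(OCC(=O)C(C)(C)C)c(C)c1` gives 18500 nM.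

Compound 3 stands at the highest number of the three. Its distance from the others is large: a 140-fold higher number from compound 1 to compound 3 (2.15 log units; beyond the scatter) and a 150-fold higher number from compound 2 to compound 3 (2.19 log units; beyond the scatter), both beyond the scatter, whereas a 1.1-fold lower number from compound 1 to compound 2 (0.03 log units; within the scatter) lies within it. On the numbers shown, the methyl(phenyl)amino on the carbonyl carbon is the one feature set apart from the two chain-bearing amides.

Compound 4 `CCn1c(C(=O)OC(C)CCO)ccc1C(CC)(CC)c1ccc(OCC(=O)C(C)(C)C)c(C)c1` is not yet measured. It differs from compound 3 as follows: a group of 6 heavy atoms (4 carbon, 2 oxygen; no ring) in place of a group of 8 heavy atoms (7 carbon, 1 nitrogen; one six-membered aromatic ring of carbon only), on a carbonyl carbon. The step thus removes the ring-bearing group that marks compound 3 and puts in a chain, so the two steps that bear on it are those into compound 3 from compound 1 and compound 2. Both were large and ran upward; reversing the distinguishing group should run the other way. Among the measured compounds shown here, no measured compound carries the entering chain on the carbonyl carbon, so the size of the return is uncertain and the range is kept wide.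

The estimate for compound 4 is 400 nM, with a range from 70 nM to 3000 nM, the expected step being a 46-fold lower number from compound 3 to compound 4 (1.67 log units; beyond the scatter).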

Compound 4, half-maximal effective concentration: 380 nM
Estimate against measurement, compound 4: 1.1-fold (0.02 log units) above; low and high end bracket the measured number.
By their numbers in this assay, from the lowest: compounds 2 and 1 (each within the scatter of the next); then compound 4; then compound 3.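

In this assay, the carbonyl carbon accepts a chain attached through oxygen rather than nitrogen, with a 49-fold lower number from compound 3 to compound 4 (1.69 log units; beyond the scatter). Neither compound 3 nor compound 4 has an amide hydrogen, so its absence alone does not separate the two. The position also distinguishes among chains, which compounds 1 and 2 alone did not show: a 3.2-fold higher number from compound 2 to compound 4 (0.50 log units; beyond the scatter) and a 2.9-fold higher number from compound 1 to compound 4 (0.47 log units; beyond the scatter) are both modest but beyond the scatter, so the return from compound 3 stops short of the level of the two chain-bearing amides. No measurement among the data gives a cause for the size of any of these steps.

As far as these compounds go, it remains open whether the phenyl ring or the methyl on the nitrogen accounts for the high number of compound 3, a question that a phenylamino group on the carbonyl carbon would help to separate. Also open, from the compounds shown here alone, is how much of the modest gap belongs to the oxygen link and how much to the chain itself, which the same chain attached through an amide nitrogen, or a carboxylic acid at its end, would begin to address.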